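A few compounds are considered here, and "the series" means these few. Any claim that something is new, unique, unknown or untested is made for them only; others in the source may bear on it.

For the measured compounds named here, in a functional assay on HT-29 cells (Homo sapiens) for antiproliferative activity, read by MTT assay, with a stated time of 96 h (a lower number here means a stronger inhibitor, a higher number a weaker inhibitor), two compounds have numbers so far. Compound 1 (`O=C1CC2(CCCCC2)Oc2c1ccc1ccccc21`) gives 6150 nM and compound 2 (`S=C(CN1CCCCC1)N/N=C1\CC2(CCCCC2)Oc2c1ccc1ccccc21`) gives 8170 nM on the same scale. Compound 2 therefore stands level with compound 1, the two numbers lying within the scatter of each other.

Compound 3 (`N/N=C1\CC2(CCCCC2)Oc2c1ccc1ccccc21`) has not yet been measured. The change from compound 2 to compound 3 (a hydrogen atom in place of a group of 9 heavy atoms (7 carbon, 1 nitrogen, 1 sulfur; one six-membered non-aromatic ring with 1 hetero atom), on an amine nitrogen) puts a hydrogen atom on an amine nitrogen in place of the group with the six-membered non-aromatic ring.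

Going by the values given here, no step between measured compounds is available to size this change. Among the compounds with values here, the only guide is that compound 1 (6150 nM) and compound 2 (8170 nM) sit level although their structures differ, so this assay is expected to show no shift beyond the scatter. The estimated change is a 1.4-fold lower number from compound 2 to compound 3 (0.13 log units; within the scatter) and it is expected to be small, with a slight lean towards a lower number. For compound 3 the estimate is 6000 nM (expected range 2000 nM to 18000 nM).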

Compound 3, half-maximal inhibitory concentration: 9970 nM
Compound 3: middle estimate off by 1.7-fold (0.22 log units), on the low side, within the range that was stated.
By their numbers in this assay, from the lowest: compounds 1, 2 and 3 (each within the scatter of the next).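

In this assay, replacing the group of 9 heavy atoms with a hydrogen atom on the amine nitrogen gives a 1.2-fold higher number from compound 2 to compound 3 (0.09 log units; within the scatter). For the compounds shown here, this is the first direct reading at this position, and it shows that the whole group, including its six-membered non-aromatic ring and its double bond outside aromatic rings, can be removed without a change beyond the scatter in this assay. No supporting measurement bears on why compound 2 and compound 3 read level.

Only a hydrogen atom and this one large group are shown at the amine nitrogen, so it remains open whether a small acetyl group, a simple methyl group, or a chain ending in a carboxylic acid would move the number beyond the scatter. Also open is whether the level reading at this position would hold on a version of the shared core carrying another substituent, such as a methoxy group, since all the compounds shown have the same core without further substitution.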